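The source may report more compounds than this note shows. Statements on the series, on what has been measured and on what is new or still open speak of the compounds shown alone.

Measured compounds:
Compound 1, `CCc1ccc(NC(=O)C2CCN(C/C=C/c3ccccc3)CC2)cc1`: 23300 nM
Compound 2, `CC(C)c1ccc(NC(=O)C2CCN(C/C=C/c3ccccc3)CC2)cc1`: 12200 nM
Compound 3, `O=C(Nc1cc(-c2cccc(Br)c2)on1)C1CCN(C/C=C/c2ccccc2)CC1`: 4420 nM

In a functional assay on HepG2 cells (Homo sapiens) for inhibition, read by MTT assay, with a stated time of 72 h (on this read-out lower numbers stand for stronger inhibition and higher numbers for weaker inhibition), compound 1 gives the highest of the three numbers. Its nearest neighbour is compound 2, with a 1.9-fold lower number from compound 1 to compound 2 (0.28 log units; within the scatter), a change of methyl in place of hydrogen on a saturated chain carbon bound to an aromatic carbon and a saturated chain carbon. Compound 3, at 4420 nM, stands furthest from it. Compound 4, `O=C(NCc1ccccc1)C1CCN(C/C=C/c2ccccc2)CC1`, differs from compound 1 by benzyl in place of 4-ethylphenyl on an amide-type nitrogen. Going by the values given here, none of the measured steps makes this kind of exchange; the one single-place step, from compound 1 to compound 2, only alters the chain on the ring and offers little guidance. The step expected is therefore modest, a 1.1-fold higher number from compound 1 to compound 4 (0.03 log units; within the scatter), with no clear direction beyond the scatter. Compound 4 is estimated at 25000 nM, within a range from 8000 nM to 80000 nM.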

Compound 4, half-maximal inhibitory concentration: > 100000 nM
Compound 4 gave a limit, no number; the forecaster's own chance of this, stated with the estimate: 20%; middle value at least 4.0-fold (0.60 log units) from the limit.
By their numbers in this assay, from the lowest: compound 3; then compounds 2 and 1 (each within the scatter of the next). At a limit, above all of these: compound 4.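

In this assay compound 4 gives a limit and not a number: the limit of > 100000 nM in this assay, at which 1 of the 4 values shown sits. Benzyl on the amide-type nitrogen gives an at least 4.2-fold higher number from compound 1 to compound 4 (0.63 log units; beyond the scatter) and an at least 8.1-fold higher number from compound 2 to compound 4 (0.91 log units; beyond the scatter) in place of the 4-alkylphenyl groups, so this position responds clearly to this exchange, which the chain change on the ring did not show. Benzyl differs from 4-ethylphenyl in two ways at once, with the ethyl gone and a carbon added in the link to the ring. The compounds shown leave open which of these matters, and a plain phenyl or a 4-ethylbenzyl on that nitrogen would separate them.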